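Swapping a sulfanyl group for a sulfonyl group

A few compounds are considered here, and "the series" means these few. Any claim that something is new, unique, unknown or untested is made for them only; others in the source may bear on it.

Values in a functional assay on DU-145 cells (Homo sapiens) for inhibition, read by trypan blue exclusion, with a stated time of 96 h (a lower number here means a stronger inhibitor of growth, a higher number a weaker inhibitor of growth), follow
- compound 1 `COc1ccccc1/C=C(/SCc1ccc(F)cc1)C(=O)c1ccc(Br)cc1` gives 10000 nM
- compound 2 `O=C(/C(=C\c1ccccc1OCc1ccccc1)Sc1ccc(F)cc1)c1ccc(Cl)cc1` gives 1000 nM
- compound 3 `COc1cc(OC)c(/C=C(\C(=O)c2ccc(Br)cc2)S(=O)(=O)c2ccc(Br)cc2)c(OC)c1` gives > 100000 nM (a limit of the assay, not a number)

Within the data shown here, only two of these readings are true numbers, and compound 2 has the lower one (1000 nM). Compound 1 stands higher (10000 nM), a gap beyond the usual scatter, so compound 2 is the stronger inhibitor of growth of that pair. The reading for compound 3 is a limit.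

The next compound to be tested is compound 4 `COc1ccc(S(=O)(=O)/C(=C/c2ccccc2OCc2ccccc2)C(=O)c2ccc(Cl)cc2)cc1`, which keeps the rest of compound 2. It carries (4-methoxyphenyl)sulfonyl in place of (4-fluorophenyl)sulfanyl on a double-bonded chain carbon bound to a carbonyl carbon and a double-bonded chain carbon.

Among the measured compounds shown here, no measured pair shows this change on its own, so any forecast rests on thin evidence. For the measured compounds named here, the only measured compound that also holds a sulfonyl group is compound 3, with its limit of > 100000 nM in this assay. That compound differs from compound 4 in other places too, so it is only a weak guide. A moderate rise in the number, beyond the scatter, therefore seems likely, meaning a weaker inhibitor of growth.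

The expected change is a 4.0-fold higher number from compound 2 to compound 4 (0.60 log units; beyond the scatter) in this assay.

For compound 4 the estimated value is 4000 nM, with an expected range from 800 nM to 30000 nM in this assay.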

Compound 4, concentration for 50% growth inhibition: 1000 nM
The estimate for compound 4 lay 4.0-fold (0.60 log units) above the measured number, within the range that was stated.
By their numbers in this assay, from the lowest: compounds 2 and 4 (each within the scatter of the next); then compound 1. At a limit, above all of these: compound 3.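

In this assay, putting (4-methoxyphenyl)sulfonyl in place of (4-fluorophenyl)sulfanyl on a double-bonded chain carbon bound to a carbonyl carbon and a double-bonded chain carbon gives no change at the digits printed from compound 2 to compound 4 (within the scatter). This position therefore accepts the larger entering group, which brings more heavy atoms and more hydrogen-bond acceptors, without a measurable loss of growth inhibition. Compound 4 also supplies the first true number for a compound holding a sulfonyl group, as the only earlier compound with that group, compound 3, gave a reading that is a limit of the assay: the limit of > 100000 nM in this assay, at which 1 of the 4 values shown sits.

This single step replaces the sulfur group and the fluorine with a methoxy group on the ring together, so the compounds shown cannot separate what each swap does alone, and a sulfanyl partner carrying the methoxy group would be needed to do so. Going by these compounds, it also remains open whether the reading would hold with an amine or a carboxylic acid in place of the methoxy group, or with a longer chain between the sulfur and the ring.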